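The compounds below may be only part of what the source reports. "The series", "measured", "known", "first", "only" and "open" are said of these compounds alone.

In a functional assay on HT-29 cells (Homo sapiens) for inhibition, read by sulforhodamine B assay, with a stated time of 48 h; on this read-out higher numbers stand for weaker inhibition of growth and lower numbers for stronger inhibition of growth:
- compound 1 `O=C(CCl)NC(=O)Nc1ccc(-c2ccccc2)cc1`: 2300 nM
- compound 2 `O=C(CCl)NC(=O)Nc1ccc(OC2CCCC2)cc1`: 3100 nM

Among the compounds with values here, compound 2 stands within the scatter of compound 1, the only other compound measured. Compound 3 `O=C(CCl)NC(=O)Nc1ccc(OCc2ccccc2)cc1` has benzyl in place of cyclopentyl on an oxygen on an aromatic ring. Within the data shown here, the one measured step that bears on this is a 1.3-fold higher number from compound 1 to compound 2 (0.13 log units; within the scatter), with cyclopentyloxy in place of phenyl on an aromatic carbon. That step stayed within the scatter, so no change beyond the scatter is expected in this assay. The expected step is a 1.1-fold lower number from compound 2 to compound 3 (0.04 log units; within the scatter). For compound 3 the estimated value is 2800 nM, with an expected range from 1300 nM to 6000 nM.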

Compound 3, concentration for 50% growth inhibition: 2600 nM
Beside the measured number, compound 3's estimate is 1.1-fold (0.03 log units) above it; the measured number falls inside the stated range.
By their numbers in this assay, from the lowest: compounds 1, 3 and 2 (each within the scatter of the next).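

In this assay benzyl in place of cyclopentyl on an oxygen on an aromatic ring gives a 1.2-fold lower number from compound 2 to compound 3 (0.08 log units; within the scatter) and so stays within the scatter. This position therefore takes a six-membered aromatic ring of carbon in place of a five-membered non-aromatic one without a change beyond the scatter. No measurement shown accounts for the two groups reading alike.

The compounds shown leave open whether an amine or a carboxylic acid on this oxygen would move the number beyond the scatter. On these data alone, a longer chain carrying such a group remains equally open.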